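Replacing the phenylsulfonyl group of compound 2

A few compounds are considered here, and "the series" means these few. Any claim that something is new, unique, unknown or untested is made for them only; others in the source may bear on it.

Values so far in a functional assay on GC3/MTK- cells (Homo sapiens) for inhibition; a lower number here means a stronger inhibitor, a higher number a weaker inhibitor:
Compound 1 `Cc1nc(O)c2cc(CNc3ccc(S(=O)(=O)c4ccccc4)cc3)ccc2n1` gives 14700 nM
Compound 2 `CCN(Cc1ccc2nc(C)nc(O)c2c1)c1ccc(S(=O)(=O)c2ccccc2)cc1` gives 2600 nM

Compound 2 holds the lower of these two numbers. Compound 3 `CCN(Cc1ccc2nc(C)nc(O)c2c1)c1ccc(C(=O)C(F)(F)F)cc1`, not yet measured, carries (trifluoromethyl)carbonyl in place of phenylsulfonyl on an aromatic carbon. Among the measured compounds shown here, the only measured step (a 5.7-fold lower number from compound 1 to compound 2 (0.75 log units; beyond the scatter)) was modest and put ethyl in place of hydrogen on a nitrogen, so it bears on this change only as a guide to size. The expected step in this assay is of similar modest size, toward a higher number, though the data fix no direction (estimated a 2.3-fold higher number from compound 2 to compound 3 (0.36 log units; beyond the scatter)). Compound 3 is expected at 6000 nM (estimated range 1500 nM to 24000 nM).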

Compound 3, half-maximal inhibitory concentration: > 4000 nM
Compound 3 gave a limit, no number (the forecaster's own chance of this, stated with the estimate: 10%); the middle value lies beyond the limit too.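

This position on the aromatic carbon, para to a large group, had not been varied before, and the result for compound 3 in this assay is a limit, > 4000 nM. Replacing phenylsulfonyl with (trifluoromethyl)carbonyl gives an at least 1.5-fold higher number from compound 2 to compound 3 (0.18 log units; that floor lies within the scatter), so the change brought no gain, though its floor does not separate the two compounds. The reading of this step ends at an assay limit: the limit of > 4000 nM in this assay, at which 1 of the 3 values shown sits.

Going by these compounds, how far compound 3 truly lies from compound 2 stays open, as does whether a nitrile or a carboxylic acid at this position would give a lower number.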